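Three flat analogues and a thiazole substitution

This account rests on a few compounds, and the source may have more. Where it says the series, first, only, none or still open, it means among the compounds named here.

The series shares one core, carried by compound 1 `O=C(Nc1ccc(Cl)cc1)C1CCCN(C(=O)c2cccc(-c3ccco3)c2)C1`, compound 2 `CSc1cccc(C(=O)N2CCCC(C(=O)Nc3ccc(Cl)cc3)C2)c1` and compound 3 `COc1cccc(C(=O)N2CCCC(C(=O)Nc3ccc(Cl)cc3)C2)c1`. In an ADME assay on PC-3 cells (Homo sapiens) for cytotoxicity, read by WST assay, tested at 100 uM (a higher number here means more inhibition at the concentration tested (going by the name of the read-out), a lower number less inhibition), compound 1 gives 0%, compound 2 gives 0% and compound 3 gives 0%. Compound 3 therefore stands level with both other measured compounds: the steps of no change at the digits printed from compound 1 to compound 3 (within the scatter) and no change at the digits printed from compound 2 to compound 3 (within the scatter) are flat, as is no change at the digits printed from compound 1 to compound 2 (within the scatter).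

Compound 4 `Cc1nc(-c2cccc(C(=O)N3CCCC(C(=O)Nc4ccc(Cl)cc4)C3)c2)cs1` is the next analogue. Its change from compound 3 is 2-methyl-1,3-thiazol-4-yl in place of methoxy on an aromatic carbon. Within the data shown here, the steps that bear on it are the three exchanges at the same place among furan-2-yl, methylsulfanyl and methoxy, none of which moved the read-out in this assay. Putting a 2-methyl-1,3-thiazol-4-yl group there instead of methoxy is therefore expected to leave the read-out flat as well. Among the measured compounds shown here, the support is thin: only three compounds, none showing any inhibition, so the data cannot exclude an upward move for a new group.

Compound 4 is expected to give 0% in this assay, with a range from 0% to 12%. This estimate corresponds to an expected step of no change at the digits printed from compound 3 to compound 4 (within the scatter).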

Compound 4, a percentage reported as inhibition, at one concentration (the size of the read-out at that concentration, not a potency): 1%
Compound 4: middle estimate off by 1 percentage points, on the low side; the range from low to high includes it.
By their numbers in this assay, from the lowest: compounds 1, 2, 3 and 4 (each within the scatter of the next).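

In this assay the aromatic carbon meta to a large group now also carries a five-membered aromatic ring with 2 hetero atoms without the read-out leaving the scatter: 2-methyl-1,3-thiazol-4-yl in place of methoxy gives a number 1 percentage points higher from compound 3 to compound 4 (within the scatter). The comparison with the other two groups reads the same, with a number 1 percentage points higher from compound 2 to compound 4 (within the scatter) against methylsulfanyl and a number 1 percentage points higher from compound 1 to compound 4 (within the scatter) against furan-2-yl, so the flat picture at this one position now covers four groups, running from the 2 heavy atoms of methoxy to the 6 heavy atoms of the thiazole, and it includes a group with both nitrogen and sulfur. Nothing measured on these compounds speaks to why the read-out stays flat here.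

From the compounds shown here alone, all four compounds lie within the scatter of one another, so the set shows no group at this position that moves the read-out, and whether an amine, a carboxylic acid or a longer alkyl chain in the same place would do so stays open. Equally open, going by these compounds, is whether a change elsewhere on the shared core, such as a fluorine or a methyl group in place of the chlorine, would shift the read-out.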